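Saturated groups in place of aryl at the hydroxy-bearing carbon

This account rests on a few compounds, and the source may have more. Where it says the series, first, only, none or still open, it means among the compounds named here.

In a functional assay on a cell-free system (plasma, Homo sapiens), with a stated time of 3 min (a lower number here means a stronger inhibitor, a higher number a weaker inhibitor), compound 1 `Cc1cccc([C@@H](O)C(=O)N2N=CC[C@H]2C(=O)NCc2cc(Cl)ccc2-n2cnnn2)c1` gives 830 nM. Compound 3 `CC(C)(C)C[C@@H](O)C(=O)N1OCC[C@H]1C(=O)NCc1cc(Cl)ccc1-n1cnnn1` gives 1100 nM and compound 2 `O=C(NCc1cc(Cl)ccc1-n1cnnn1)[C@@H]1CCON1C(=O)[C@H](O)c1ccccc1` gives 1500 nM in this assay; all three numbers lie within the scatter of one another. Compound 4 `O=C(NCc1cc(Cl)ccc1-n1cnnn1)[C@@H]1CC=NN1C(=O)[C@H](O)C1CCCCC1` carries the change (cyclohexyl in place of 3-methylphenyl on a saturated chain carbon bound to a carbonyl carbon and an oxygen on a saturated carbon). Going by the values given here, the one measured step that bears on it is a 1.4-fold lower number from compound 2 to compound 3 (0.13 log units; within the scatter), where a saturated group likewise replaced an aromatic one at the same place. No step beyond the scatter is therefore expected for compound 4 in this assay, with the estimate a 1.1-fold lower number from compound 1 to compound 4 (0.04 log units; within the scatter). The number for compound 4 is estimated at 750 nM, within 350 nM to 1600 nM.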

Compound 4, half-maximal inhibitory concentration: 970 nM
For compound 4 the middle estimate is 1.3-fold (0.11 log units) below the measured one, and the stated range covers the measured number.
By their numbers in this assay, from the lowest: compounds 1, 4, 3 and 2 (each within the scatter of the next).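

In this assay, cyclohexyl in place of 3-methylphenyl gives a 1.2-fold higher number from compound 1 to compound 4 (0.07 log units; within the scatter). Read with a 1.4-fold lower number from compound 2 to compound 3 (0.13 log units; within the scatter), this shows a saturated ring, as well as an open saturated chain, replacing an aromatic ring at this carbon with no step beyond the scatter, now on the core of compound 1. No measured evidence on the origin of this result is at hand. Open, from the compounds shown here alone, is whether an amine or a carboxylic acid on this cyclohexyl ring would stay within the scatter. Also open, going by these compounds, is how neopentyl and cyclohexyl compare on one core.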